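One Stereocentre Changed: From Compound 2 to Compound 4

This account rests on a few compounds, and the source may have more. Where it says the series, first, only, none or still open, it means among the compounds named here.

Measured so far in a functional assay (Hepatocyte) for inhibition, with Rattus norvegicus as the target (a higher number here means a weaker inhibitor, a lower number a stronger inhibitor), are three compounds:
- compound 1 `C=C1C[C@@H]1CC(=O)O` gives 60000 nM
- compound 2 `C=C1[C@@H](CC(=O)O)[C@H]1CCCC` gives 15000 nM
- compound 3 `C=C1[C@@H](CC(=O)O)[C@H]1CCCCCCCC` gives 5000 nM

Compound 2 holds the middle of these three numbers, below compound 1 and above compound 3. The next compound to be tested is compound 4 `C=C1[C@H](CCCC)[C@H]1CC(=O)O` and its change from compound 2 is this: the two compounds have the same atoms and bonds and differ only in configuration as drawn: 1 of 2 stereo elements differ; a stereocentre at a saturated ring carbon is drawn S in compound 2 and R in compound 4 with nothing else altered.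

Two measured steps are available, a 4.0-fold lower number from compound 1 to compound 2 (0.60 log units; beyond the scatter) and a 3.0-fold lower number from compound 2 to compound 3 (0.48 log units; beyond the scatter) and both are modest. Each adds butyl, and neither changes configuration alone, so they bear on this question only as a guide to how large steps run in this assay for these compounds. Within the data shown here, the data hold no pair that differs in configuration alone, and they give no direction. The expectation is therefore no step beyond the scatter, although a modest step either way remains possible. The estimated step is no change at the digits printed from compound 2 to compound 4 (within the scatter) and it is no more than a working expectation. Compound 4 is estimated at 15000 nM with a range from 6000 nM to 40000 nM expected.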

Compound 4, half-maximal inhibitory concentration: 30000 nM
For compound 4 the middle estimate is 2.0-fold (0.30 log units) below the measured one; measured number inside the range.
By their numbers in this assay, from the lowest: compound 3; then compounds 2, 4 and 1 (each within the scatter of the next, the first and the last beyond it).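

Among these compounds, the first pair in this set that isolates configuration at this saturated ring carbon reads, in this assay, as a 2.0-fold higher number from compound 2 to compound 4 (0.30 log units; within the scatter). Drawing this stereocentre S or R therefore gives numbers that cannot be told apart in this assay, whereas the two butyl steps, a 4.0-fold lower number from compound 1 to compound 2 (0.60 log units; beyond the scatter) and a 3.0-fold lower number from compound 2 to compound 3 (0.48 log units; beyond the scatter), both lie beyond the scatter. This comparison rests on a single structural difference: the fact that compounds 2 and 4 differ only in the configuration as drawn

The compounds shown leave open whether inverting the other stereocentre, or making the same inversion with the longer chain of compound 3, would give a step beyond the scatter. They also leave open how an amine or an amide would read in this assay in place of the carboxylic acid.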